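The source may hold more compounds than are shown below. What is called first, only, known or untested is meant among the compounds shown, and "the series" means these compounds.

Compound 1 `COc1cc(-c2nc3cc(/C=C4\SC(=O)N(CC(=O)N5CCCCC5)C4=O)ccc3[nH]2)cc(OC)c1OC` has the lowest of the two numbers in a functional assay on A549 cells (Homo sapiens) for inhibition, read by MTT assay, with a stated time of 48 h (on this read-out lower numbers stand for stronger inhibition and higher numbers for weaker inhibition), where compound 1 gives 980 nM. Its nearest neighbour, compound 2 `COc1cc(OC)c(-c2nc3cc(/C=C4\SC(=O)N(CC(=O)N5CCCCC5)C4=O)ccc3[nH]2)cc1OC`, gives 14500 nM in this assay, and the change is a 15-fold higher number from compound 1 to compound 2 (1.17 log units; beyond the scatter). Compound 3 `COc1cc(CN2C(=O)S/C(=C\c3ccc4[nH]c(-c5cc(OC)c(OC)c(OC)c5)nc4c3)C2=O)cc(OC)c1OC` differs from compound 1 by 3,4,5-trimethoxyphenyl in place of (piperidin-1-yl)carbonyl on a saturated chain carbon bound to an amide-type nitrogen in a ring. Within the data shown here, no measured step touches that position; the one step seen concerns a different ring, so it does not bear on this change. Compound 3 is therefore expected to show a step of a 1.5-fold higher number from compound 1 to compound 3 (0.18 log units; within the scatter), with wide uncertainty. The estimate for compound 3 is 1500 nM, ranging from 300 nM to 8000 nM.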

Compound 3, half-maximal inhibitory concentration: 530 nM
Compound 3: middle estimate off by 2.8-fold (0.45 log units), on the high side, within the range that was stated.
By their numbers in this assay, from the lowest: compounds 3 and 1 (each within the scatter of the next); then compound 2.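

Placing 3,4,5-trimethoxyphenyl in place of (piperidin-1-yl)carbonyl on the saturated chain carbon bound to an amide-type nitrogen in a ring gives a 1.8-fold lower number from compound 1 to compound 3 (0.27 log units; within the scatter) in this assay. This position therefore takes either a non-aromatic ring or a larger aromatic one with no step beyond the scatter, unlike the large step seen earlier on the other ring. Nothing here explains why.

On these data alone, whether a carboxylic acid or an amine at this position would hold the number remains open. So does whether 2,4,5-trimethoxyphenyl would cost as much alongside this new group.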